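The source may report more compounds than this note shows. Statements on the series, on what has been measured and on what is new or still open speak of the compounds shown alone.

Within the data shown here, compound 3 `N#CC1=C(N)N(c2ccc(S(N)(=O)=O)cc2)C2=C(C(=O)CCC2)C1c1ccc(Cl)cc1Cl` stands, in a functional assay on Ehrlich cells (Mus musculus) for antiproliferative activity, read by trypan blue exclusion, with a stated time of 2 h, tested at 25 ug/mL (a higher number here means a stronger effect of the compound at the concentration tested, a lower number a weaker effect), at 50%, level with compound 2 `N#CC1=C(N)N(c2ccc(S(N)(=O)=O)cc2)C2=C(C(=O)CCC2)C1c1cccc([N+](=O)[O-])c1`, which gives 50%, and the two together are the highest of the three numbers so far; compound 1 `COc1ccccc1C1C(C#N)=C(N)N(c2ccc(S(N)(=O)=O)cc2)C2=C1C(=O)CCC2` gives 0%. The step of a number 50 percentage points higher from compound 1 to compound 3 (beyond the scatter) and the step of no change at the digits printed from compound 2 to compound 3 (within the scatter) describe how compound 3 is placed. Compound 4 `COc1ccc2ccccc2c1C1C(C#N)=C(N)N(c2ccc(S(N)(=O)=O)cc2)C2=C1C(=O)CCC2` differs from compound 3 in one place: 2-methoxynaphthalen-1-yl in place of 2,4-dichlorophenyl on a saturated ring carbon. Among the measured compounds shown here, no measured step replaces a phenyl ring by a naphthyl ring, so the bearing steps are only indirect; the step of a number 50 percentage points higher from compound 1 to compound 2 (beyond the scatter) and the step of a number 50 percentage points higher from compound 1 to compound 3 (beyond the scatter) show that a 2-methoxyphenyl group gave the lowest number, and compound 4 carries a methoxy-bearing aryl again. Compound 4 is therefore expected to fall between those outcomes, with the step of a number 25 percentage points lower from compound 3 to compound 4 (beyond the scatter) expected downward, to an estimated 25% within 0% to 50%.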

Compound 4, a percentage reported as activity, at one concentration (the size of the read-out at that concentration, not a potency): 62%
The estimate for compound 4 lay 37 percentage points below the measured number; measured number outside the range, above it.
By their numbers in this assay, from the lowest: compound 1; then compounds 2 and 3 (each within the scatter of the next); then compound 4.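

In this assay, a methoxy-bearing aryl group on this saturated ring carbon does not by itself give the low reading of compound 1: replacing 2-methoxyphenyl with 2-methoxynaphthalen-1-yl gives a number 62 percentage points higher from compound 1 to compound 4 (beyond the scatter) in this series. The same group also improves on the other two aryl groups, with a number 12 percentage points higher from compound 3 to compound 4 (beyond the scatter) and a number 12 percentage points higher from compound 2 to compound 4 (beyond the scatter), which leaves compound 4 the highest of the four. Nothing given here accounts for these rises. Going by these compounds, whether the second aromatic ring or the methoxy group matters more remains open, and a plain naphthalen-1-yl group or a 2-hydroxynaphthalen-1-yl group at this position would separate the two.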